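Notes on the step from compound 2 to compound 4

This account rests on a few compounds, and the source may have more. Where it says the series, first, only, none or still open, it means among the compounds named here.

Values in an ADME assay on MCF7-DOX cells (Homo sapiens) for cytotoxicity, read by MTT assay, with a stated time of 48 h (a higher number here means a weaker inhibitor, a lower number a stronger inhibitor), so far
- compound 1 `COc1cc(OC)c(C(=O)/C=C/c2ccc(C(F)(F)F)cc2)c(O)c1CC=C(C)C` gives 73700 nM
- compound 2 `COc1cc(OC)c(C(=O)/C=C/c2cccc([N+](=O)[O-])c2)c(O)c1CC=C(C)C` gives 57000 nM
- compound 3 `COc1cc(OC)c(C(=O)/C=C/c2cccc(N3CCN(C)CC3)c2)c(O)c1CC=C(C)C` gives > 100000 nM (a limit of the assay, not a number)

Compound 2 stands level with compound 1 within the scatter, and compound 3 offers only a limit for comparison. Compound 4 `COc1cc(OC)c(C(=O)/C=C/c2ccc(F)cc2)c(O)c1CC=C(C)C` carries 4-fluorophenyl in place of 3-nitrophenyl on a double-bonded chain carbon bound to a double-bonded chain carbon. Within the data shown here, two measured steps bear on this change. The exchange at that same place, 3-nitrophenyl in place of 4-(trifluoromethyl)phenyl, gave a 1.3-fold lower number from compound 1 to compound 2 (0.11 log units; within the scatter). Putting 4-methylpiperazin-1-yl in place of nitro gave an at least 1.7-fold higher number from compound 2 to compound 3 (0.24 log units; that floor lies within the scatter), which is a floor only. Neither step supports a direction in this assay for the new exchange, so no change beyond the scatter is expected. The expected step is a 1.1-fold higher number from compound 2 to compound 4 (0.02 log units; within the scatter), with no direction claimed. For compound 4 the estimated value is 60000 nM, with an expected range from 30000 nM to 100000 nM.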

Compound 4, half-maximal inhibitory concentration: 53700 nM
Compound 4: middle estimate off by 1.1-fold (0.05 log units), on the high side; measured number inside the range.
By their numbers in this assay, from the lowest: compounds 4, 2 and 1 (each within the scatter of the next). At a limit, above all of these: compound 3.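

In this assay, 4-fluorophenyl on a double-bonded chain carbon bound to a double-bonded chain carbon gives a 1.1-fold lower number from compound 2 to compound 4 (0.03 log units; within the scatter), and fluoro in place of trifluoromethyl on an aromatic carbon gives a 1.4-fold lower number from compound 1 to compound 4 (0.14 log units; within the scatter), so the new compound stays level with both earlier ones. Across compound 1, compound 2 and compound 4, the aromatic group at this place shows no step beyond the scatter, whether it carries nitro, trifluoromethyl or fluoro. No measured property shown here bears on this level result.

Going by these compounds, compound 3 gives > 100000 nM, a limit of the assay and not a number, so the size of the step to 4-methylpiperazin-1-yl stays unknown. On these data alone, whether a carboxylic acid or a methoxy group on that aromatic ring would move the number beyond the scatter remains open.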